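This account rests on a few compounds, and the source may have more. Where it says the series, first, only, none or still open, it means among the compounds named here.

Three compounds sharing one core have been measured in a functional assay on HEL cells (Homo sapiens) for cytotoxicity; a lower number here means a stronger inhibitor, a higher number a weaker inhibitor:

Compound 1 `O=C1O/C(=C\Cn2cc(I)c(=O)[nH]c2=O)C(OCc2ccccc2)=C1OCc1ccccc1`: 3000 nM
Compound 2 `O=C1O/C(=C\Cn2cc(Cl)c(=O)[nH]c2=O)C(OCc2ccccc2)=C1OCc1ccccc1`: 3000 nM
Compound 3 `O=C1O/C(=C\Cn2cc(Br)c(=O)[nH]c2=O)C(OCc2ccccc2)=C1OCc1ccccc1`: 3000 nM

On these numbers, compound 3 stands level with compound 1 and compound 2, and none of the three separates from the others. Compound 4 `O=C1O/C(=C\Cn2cc(F)c(=O)[nH]c2=O)C(OCc2ccccc2)=C1OCc1ccccc1` keeps the core of compound 3 and differs from it in a single substitution: fluoro in place of bromo on an aromatic carbon. All three measured steps bear on this change, each exchanging one halogen for another on the same aromatic carbon: no change at the digits printed from compound 1 to compound 2 (within the scatter), no change at the digits printed from compound 1 to compound 3 (within the scatter) and no change at the digits printed from compound 2 to compound 3 (within the scatter). Each of them stays within the scatter. For the measured compounds named here, no fluoro compound has yet been measured, so this is an extrapolation and the range is kept wide. The step expected in this assay is no change at the digits printed from compound 3 to compound 4 (within the scatter), with no direction and no size beyond the scatter anticipated. The estimated value for compound 4 is 3000 nM, with an expected range of 1000 nM to 6000 nM.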

Compound 4, half-maximal inhibitory concentration: 9000 nM
Estimate against measurement, compound 4: 3.0-fold (0.48 log units) below; the whole stated range lies below it.
By their numbers in this assay, from the lowest: compounds 1, 2 and 3 (each within the scatter of the next); then compound 4.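

In this assay this aromatic carbon does not treat every halogen alike: fluoro in place of bromo gives a 3.0-fold higher number from compound 3 to compound 4 (0.48 log units; beyond the scatter) and fluoro in place of chloro gives a 3.0-fold higher number from compound 2 to compound 4 (0.48 log units; beyond the scatter) and fluoro in place of iodo gives a 3.0-fold higher number from compound 1 to compound 4 (0.48 log units; beyond the scatter) and all three steps are modest. The iodo, chloro and bromo compounds stay within the scatter of one another, so among these four halogens only fluoro stands apart, on the side of the weaker inhibitor. Nothing available here bears on why fluoro parts from the other three halogens.

The compounds shown carry only halogens at this carbon, which leaves open how a hydrogen, a methyl, an amine or a nitrile there would read in this assay on this core. They also leave open whether fluoro would stay apart from the other halogens on a different core.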